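A few compounds are considered here, and "the series" means these few. Any claim that something is new, unique, unknown or untested is made for them only; others in the source may bear on it.

Measured in a functional assay on ECa-109 cells for inhibition, with ECa-109 cell line (Homo sapiens) as the target, read by sulforhodamine B assay; a higher number here means a weaker inhibitor, a lower number a stronger inhibitor:
- Compound 1 `CCCc1ccc(NC2=CC(=O)c3nc4n(c3C2=O)[C@H]2OC[C@@H](O)[C@H]2OC4)cc1`: > 4000 nM (a limit)
- Compound 2 `O=C1C(Nc2ccccc2)=CC(=O)c2c1nc1n2[C@H]2OC[C@@H](O)[C@H]2OC1`: 3560 nM
- Compound 3 `O=C1C(NC2CCCC2)=CC(=O)c2c1nc1n2[C@H]2OC[C@@H](O)[C@H]2OC1`: > 16000 nM (a limit)

Compound 1 has no exact number in this assay, only the limit > 4000 nM. Compound 4 `CCc1ccc(NC2=CC(=O)c3nc4n(c3C2=O)[C@H]2OC[C@@H](O)[C@H]2OC4)cc1` shortens its 4-propylphenyl group to 4-ethylphenyl, with hydrogen in place of methyl on a saturated chain carbon, two bonds along the chain from an aromatic carbon. Within the data shown here, no measured step changes this chain. Among the measured compounds shown here, the only measured step, an at least 4.4-fold higher number from compound 2 to compound 3 (0.65 log units; beyond the scatter), puts cyclopentyl in place of phenyl on an amine nitrogen, so it bears on this change only weakly and its size does not carry over. The closer guide is compound 2, which has phenyl without the chain and gives 3560 nM. On that basis, no step beyond the scatter is expected in this assay. The estimated step is a step that the limit leaves unreadable from compound 1 to compound 4. Compound 4 is expected at 4500 nM, with an estimated range of 1800 nM to 14000 nM.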

Compound 4, half-maximal inhibitory concentration: 3080 nM
For compound 4 the middle estimate is 1.5-fold (0.16 log units) above the measured one, and the stated range covers the measured number.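

In this assay, among these compounds, the change from 4-propylphenyl to 4-ethylphenyl gives an at least 1.2-fold lower number from compound 1 to compound 4 (0.11 log units; that floor lies within the scatter) and so shows no step that can be told apart from the scatter. From the compounds shown here alone, the true size of this step stays unknown, because compound 1 has only a limit: the limit of > 4000 nM in this assay, at which 1 of the 4 values shown sits.

What is new is an exact number for a phenyl group that carries a chain: compound 4 gives 3080 nM and stands close to compound 2, which has no chain, at 3560 nM in the same assay.

The compounds shown leave open whether a methyl group in place of the ethyl group would change the number beyond the scatter. They also leave open what a carboxylic acid or an amine at the end of the chain would do.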